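A Hydroxy Added to the Sugar Ring on Two Cores

A few compounds are considered here, and "the series" means these few. Any claim that something is new, unique, unknown or untested is made for them only; others in the source may bear on it.

Compound 1, `Cc1nsc2c1nc(SCc1ccccc1)n2[C@H]1C[C@H](O)[C@@H](CO)O1`, gives > 100000 nM in a functional assay on HFF cells (Homo sapiens) for inhibition; on this read-out lower numbers stand for stronger inhibition and higher numbers for weaker inhibition; this is a limit of the assay. Compound 2, `CSc1nc2sncc2n1[C@H]1C[C@H](O)[C@@H](CO)O1`, gives 15000 nM in this assay. Compound 3, `Cc1nsc2c1nc(SCc1ccccc1)n2[C@@H]1O[C@H](CO)[C@@H](O)[C@@H]1O`, gives > 100000 nM in this assay; this too is a limit of the assay.

Compound 3 differs from compound 1 by hydroxy in place of hydrogen on a saturated ring carbon. The size of this step, a step that the two limits leave unreadable from compound 1 to compound 3, cannot be read because the limit of > 100000 nM in this assay, at which 2 of the 3 values shown sit, holds both ends of it. For the measured compounds named here, compound 2 is the one compound of the three with a measured number rather than a limit. How the core of compound 2 differs from the core of compound 1 is not broken down here.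

Compound 4, `CSc1nc2sncc2n1[C@@H]1O[C@H](CO)[C@@H](O)[C@@H]1O`, is not yet measured. It differs from compound 2 by hydroxy in place of hydrogen on a saturated ring carbon, the same change as that from compound 1 to compound 3. Going by the values given here, the pair already measured gives no size for the change, since both of its members sit at a limit; the only anchor for compound 4 is the number given by compound 2 in this assay. The expected step of a 2.0-fold higher number from compound 2 to compound 4 (0.30 log units; within the scatter) is therefore set near no change, with a wide range around it, resting on compound 2 and its value 15000 nM and on the unreadable step from compound 1 to compound 3. For compound 4 the estimated value is 30000 nM, expected to fall between 8000 nM and 100000 nM.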

Compound 4, half-maximal inhibitory concentration: 21000 nM
Compound 4: the middle estimate sits 1.4-fold (0.15 log units) above what was measured, within the range that was stated.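

On the core of compound 2, hydroxy in place of hydrogen on a saturated ring carbon gives a 1.4-fold higher number from compound 2 to compound 4 (0.15 log units; within the scatter) in this assay, so this read-out does not separate the two compounds on this core. On the core of compound 1, the same change cannot be sized, since compound 1 and compound 3 both stand at a limit of the assay: the limit of > 100000 nM in this assay, at which 2 of the 4 values shown sit. The series shown therefore holds a single readable case of this change, which does not show whether the result on one core carries over to the other, and the two cores cannot be compared for it.

The compounds shown leave open whether an amine in place of the hydroxy on the same ring carbon of the five-membered ring would give a number that stands apart from those of compound 2 and compound 4. They also leave open what a longer chain, such as ethyl or propyl, in place of the methyl on sulfur would give on the core of compound 2, and whether a change of that kind would bring the core of compound 1 into the readable range of the assay.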